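Replacing a small amide substituent on the weakest urea

The source may hold more compounds than are shown below. What is called first, only, known or untested is meant among the compounds shown, and "the series" means these compounds.

Measured compounds:
- compound 1 `Cc1ccc(-n2nc(C(C)(C)C)cc2NC(=O)Nc2cc(-c3ccc4nccnc4c3)[nH]n2)cc1`: 62 nM
- compound 2 `CNC(=O)c1cc2cccc(NC(=O)Nc3cc(C(C)(C)C)nn3-c3ccc(C)cc3)c2[nH]1`: 2780 nM
- compound 3 `COc1ccc(-c2cc(NC(=O)Nc3cc(C(C)(C)C)nn3-c3ccc(C)cc3)n[nH]2)nc1`: 607 nM

All three share a urea linking a tert-butyl pyrazole to a second ring system, and all were tested in an assay on NIH3T3 cells for inhibition of protein-tyrosine kinase 2-beta (Mus musculus); a lower number here means a stronger inhibitor, a higher number a weaker inhibitor. Compound 2 gives the highest number of the three: compound 3 gives 607 nM and compound 1 gives 62 nM, both clearly lower than the value of compound 2, so compound 2 is the weakest inhibitor in this set.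

Compound 4 `Cc1ccc(-n2nc(C(C)(C)C)cc2NC(=O)Nc2cccc3cc(C(=O)N4CCC5(CCNC5)C4)[nH]c23)cc1` keeps the core of compound 2 and changes only the amide end: a group of 9 heavy atoms (7 carbon, 2 nitrogen; 2 five-membered non-aromatic rings with 1 hetero atom each) in place of a group of 2 heavy atoms (1 carbon, 1 nitrogen; no ring), on a carbonyl carbon. For the measured compounds named here, the one step measured so far, a 9.8-fold higher number from compound 1 to compound 3 (0.99 log units; beyond the scatter), concerns an exchange of aromatic rings on a different compound and a different position, so it gives no direct guidance on what a larger amide substituent does here. Going by the values given here, with no comparable step available, the expectation for compound 4 rests on the value of compound 2 alone, allowing a broad margin in either direction.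

Compound 4 is therefore estimated at 1500 nM in this assay, within a range of 300 nM to 8000 nM. That estimate corresponds to an expected step of a 1.9-fold lower number from compound 2 to compound 4 (0.27 log units; within the scatter), which cannot be told apart from no change with confidence.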

Compound 4, half-maximal inhibitory concentration: 7660 nM
The estimate for compound 4 lay 5.1-fold (0.71 log units) below the measured number; the measured number falls inside the stated range.
By their numbers in this assay, from the lowest: compound 1; then compound 3; then compound 2; then compound 4.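

For the compounds shown here, at the amide end of the shared core, putting the larger group with 2 five-membered non-aromatic rings in place of methylamino gives a 2.8-fold higher number from compound 2 to compound 4 (0.44 log units; beyond the scatter) in this assay, the first measured change at this carbonyl carbon, and it moves towards weaker inhibition. The loss is modest but real, and compound 4 still gives a measurable number of 7660 nM, so this much larger group does not abolish inhibition. No measured property of these groups is available to account for the rise.

With only these two amides at this position, the effect of size cannot be separated from the other differences between the groups. A carboxylic acid, a dimethylamino group or a longer open aminoalkyl chain on the same carbonyl carbon would show whether the rise follows the ring system or the group's size.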